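Plasma inhibitors: cyclopropylmethyl in place of 3-fluorophenyl

This account rests on a few compounds, and the source may have more. Where it says the series, first, only, none or still open, it means among the compounds named here.

Measured compounds in a functional assay on a cell-free system (plasma, Homo sapiens), with a stated time of 3 min; on this read-out higher numbers stand for weaker inhibition and lower numbers for stronger inhibition:
compound 1 `O=C(NCc1cc(Cl)ccc1-n1cnnn1)[C@@H]1C[C@H]2C[C@H]2N1C(=O)[C@H](O)c1cccc(F)c1`, 1100 nM
compound 2 `O=C(NCc1cc(Cl)ccc1-n1cnnn1)[C@@H]1C[C@@H]2C[C@@H]2N1C(=O)[C@H](O)c1ccccc1F`, 770 nM
compound 3 `CC(C)(C)OC[C@@H](O)C(=O)N1C[C@@H]2C[C@@H]2[C@H]1C(=O)NCc1cc(Cl)ccc1-n1cnnn1`, 570 nM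

Compound 1 carries the highest number of the three, but its gaps to compound 2 and to compound 3 both lie within the scatter, so the three are not separated. Compound 4 `O=C(NCc1cc(Cl)ccc1-n1cnnn1)[C@@H]1C[C@H]2C[C@H]2N1C(=O)[C@H](O)CC1CC1` has not been measured. It differs from compound 1 in one place: cyclopropylmethyl in place of 3-fluorophenyl on a saturated chain carbon bound to a carbonyl carbon and an oxygen on a saturated carbon. Going by the values given here, no measured pair shows this change. Compound 3, which gives 570 nM, suggests an aromatic ring in that place is not required. A small step is expected, toward a weaker or unchanged result: a 1.4-fold higher number from compound 1 to compound 4 (0.13 log units; within the scatter). Compound 4 is estimated at 1500 nM, within 500 nM to 4500 nM.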

Compound 4, half-maximal inhibitory concentration: 850 nM
Estimate against measurement, compound 4: 1.8-fold (0.25 log units) above; measured number inside the range.
By their numbers in this assay, from the lowest: compounds 3, 2, 4 and 1 (each within the scatter of the next).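

In this assay, cyclopropylmethyl in place of 3-fluorophenyl gives a 1.3-fold lower number from compound 1 to compound 4 (0.11 log units; within the scatter) and stays within the scatter, so on the core of compound 1 this place tolerates a non-aromatic three-membered ring as well as a six-membered aromatic ring. Going by these compounds alone, this is the first direct comparison at this place, and it shows that the aromatic ring is not required to keep inhibition at this level. No available evidence explains this tolerance.

On these data alone, whether an amine, a carboxylic acid or a longer chain at this place would shift the number beyond the scatter remains open. The compounds shown also do not reveal which groups here would give a clearly stronger or weaker result.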